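Aryl substituent variation in a nitrile legumain series

The compounds below may be only part of what the source reports. "The series", "measured", "known", "first", "only" and "open" are said of these compounds alone.

Measured so far:
compound 1 `C[C@@H](C(=O)N[C@H](C#N)CC(N)=O)N(Cc1ccc(-c2cc(F)cc(F)c2)cc1)S(C)(=O)=O` gives 1360 nM
compound 2 `C[C@@H](C(=O)N[C@H](C#N)CC(N)=O)N(Cc1ccc(-c2cccc(C(F)(F)F)c2)cc1)S(C)(=O)=O` gives 601 nM
compound 3 `C[C@H](C(=O)N[C@H](C#N)CC(N)=O)N(Cc1ccc(-c2cccc(C(F)(F)F)c2)cc1)S(C)(=O)=O` gives only a limit of the assay, > 10000 nM

In an assay on isolated protein for inhibition of legumain (Homo sapiens), with stated times of 2 min and 60 min (on this read-out lower numbers stand for stronger inhibition and higher numbers for weaker inhibition), compound 2 has the lowest of the two numbers shown; the step of a 2.3-fold lower number from compound 1 to compound 2 (0.35 log units; beyond the scatter) is modest. The large step of an at least 16-fold higher number from compound 2 to compound 3 (1.22 log units; beyond the scatter) goes with the fact that compounds 2 and 3 differ only in the configuration as drawn and with the limit of > 10000 nM in this assay, at which 1 of the 3 values shown sits, so it does not speak to the aryl change.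

Compound 4 `C[C@@H](C(=O)N[C@H](C#N)CC(N)=O)N(Cc1ccc(-c2ccc(F)c(F)c2)cc1)S(C)(=O)=O` differs from compound 2 by 3,4-difluorophenyl in place of 3-(trifluoromethyl)phenyl on an aromatic carbon. Going by the values given here, the only measured step that bears on this change is the modest one from the 3,5-difluorophenyl analogue, compound 1, to compound 2. Swapping back to a difluorophenyl is therefore expected to raise the number modestly, a 1.8-fold higher number from compound 2 to compound 4 (0.26 log units; within the scatter). For compound 4 the estimate in this assay is 1100 nM, expected to fall between 450 nM and 2700 nM.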

Compound 4, half-maximal inhibitory concentration: 252 nM
Compound 4: the middle estimate sits 4.4-fold (0.64 log units) above what was measured; the whole stated range lies above it.
By their numbers in this assay, from the lowest: compound 4; then compound 2; then compound 1. At a limit, above all of these: compound 3.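

In this assay, 3,4-difluorophenyl gives the lowest number among the aryl groups shown, with a 2.4-fold lower number from compound 2 to compound 4 (0.38 log units; beyond the scatter) and with a 5.4-fold lower number from compound 1 to compound 4 (0.73 log units; beyond the scatter) both beyond the scatter. The two difluorophenyl patterns now fall on either side of 3-(trifluoromethyl)phenyl, so the placement of the two fluorines on this ring matters more here than the swap between difluorophenyl and trifluoromethyl-bearing aryl groups. Nothing at hand gives a cause for these steps.

Going by these compounds, whether a methoxy group, an amine or a carboxylic acid on this aryl ring would hold or lower the number remains open.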